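This account rests on a few compounds, and the source may have more. Where it says the series, first, only, none or still open, it means among the compounds named here.

Measured so far in an ADME assay on the whole organism for metabolic stability, with Mus musculus as the target, at a dose of 5 mg/kg by the intravenous route; a higher number here means that the compound lasts longer, a lower number that the compound disappears faster:
compound 1 `CNC(=O)c1ccc(-c2cnc3cnc(C(=O)N(C)c4ccc(C#N)cc4)cn23)cc1` gives 0.42 h;
compound 2 `CN(C(=O)c1cn2c(-c3ccc(-c4nnc(N)s4)cc3)cnc2cn1)c1ccc(C#N)cc1` gives 2.12 h.

Among the compounds with values here, compound 1 holds the lowest of the two numbers; the only other number lies a 5.0-fold higher number from compound 1 to compound 2 (0.70 log units; beyond the scatter). Compound 3 `CNC(=O)c1ccc(-c2cnc3cnc(C(=O)N(C)c4ccc(Cl)cc4)cn23)cc1` differs from compound 1 by chloro in place of cyano on an aromatic carbon. Within the data shown here, the single measured step changes a different part of the molecule, so no measured step bears directly on this exchange, and in this assay no step beyond the scatter is expected from it. Compound 3 is thus expected close to its parent, at an estimated 0.5 h, within a range from 0.2 h to 1.3 h. The expected step is a 1.2-fold higher number from compound 1 to compound 3 (0.08 log units; within the scatter).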

Compound 3, half-life: 0.83 h
Estimate against measurement, compound 3: 1.7-fold (0.22 log units) below; low and high end bracket the measured number.
By their numbers in this assay, from the lowest: compounds 1 and 3 (each within the scatter of the next); then compound 2.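

Within the data shown here, the earlier step changed a different part of the molecule, so this is the first reading at the 4-cyanophenyl group. In this assay, 4-chlorophenyl in its place gives a step that cannot be told apart from repeated measurement (a 2.0-fold higher number from compound 1 to compound 3 (0.30 log units; within the scatter)). Nothing measured here offers an explanation for this result.

Still open, on these data alone, is how other groups in this place, such as an amine or a carboxylic acid, would read in this assay. Also open, as far as these compounds go, is whether chloro would read the same alongside 5-amino-1,3,4-thiadiazol-2-yl.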